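A Cyclohexyl Ring Replaces a Hexyloxy Group

The compounds below may be only part of what the source reports. "The series", "measured", "known", "first", "only" and "open" are said of these compounds alone.

Of the compounds shown here, two have been measured so far in an assay on cells for antagonist activity at transient receptor potential cation channel subfamily V member 1 (Homo sapiens), read by FLIPR and calcium flux, with a stated time of 6 min; on this read-out higher numbers stand for weaker inhibition and lower numbers for stronger inhibition. Compound 1 `CC(C(=O)NCc1ccc(C(C)(C)C)nc1SC1CCCC1)c1ccc(NS(C)(=O)=O)c(F)c1` gives 2.5 nM in this assay. Compound 2 `CCCCCCOc1cc(C(C)(C)C)ccc1CNC(=O)C(C)c1ccc(NS(C)(=O)=O)c(F)c1` gives 0.5 nM in this assay, the lowest of the two numbers, and its gap to compound 1 lies beyond the scatter, so compound 2 stands as the stronger inhibitor of the pair.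

Compound 3 `CC(C(=O)NCc1ccc(C(C)(C)C)cc1C1CCCCC1)c1ccc(NS(C)(=O)=O)c(F)c1` has not yet been measured. Relative to compound 2 it shows one change: cyclohexyl in place of hexyloxy on an aromatic carbon. Among the measured compounds shown here, no measured pair shares this change, so nothing among the existing numbers tells how this assay reads it; the comparison of compound 1 with compound 2 concerns a different part of the molecule and gives no direct guide.

With the hexyloxy group removed and a cyclohexyl ring put in its place, a modest move toward a higher number is expected, of a size that may not exceed the scatter. The step expected is a 2.4-fold higher number from compound 2 to compound 3 (0.38 log units; beyond the scatter). Compound 3 is expected to give 1.2 nM, within a range from 0.35 nM to 4.5 nM.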

Compound 3, inhibition constant: 9.8 nM
The estimate for compound 3 lay 8.2-fold (0.91 log units) below the measured number; measured number outside the range, above it.
By their numbers in this assay, from the lowest: compound 2; then compound 1; then compound 3.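

In this assay, the change at this aromatic carbon, ortho to a large group and meta to a tert-butyl group, gives a 20-fold higher number from compound 2 to compound 3 (1.29 log units; beyond the scatter), a large step that shows this position is far from indifferent to which group it carries. Hexyloxy has 7 heavy atoms and cyclohexyl has 6, so two groups that are close in heavy-atom count still read very differently here, although the change also swaps an open chain with a hydrogen-bond acceptor for a ring of carbon only. Nothing measured here accounts for the size of this step, and the pair alone cannot separate the loss of the oxygen from the closing of the ring.

The compounds shown leave open whether the oxygen or the open chain matters more, a question that a cyclohexyloxy group or a plain heptyl chain on the same carbon would help to settle. They also leave open how the number follows chain length at this position, for example with a shorter butoxy group or a longer octyloxy group in place of hexyloxy.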